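Methylating the phenol: one change made twice

The source may hold more compounds than are shown below. What is called first, only, known or untested is meant among the compounds shown, and "the series" means these compounds.

Compound 1 `COc1cc(/C=N/NC(=O)OCc2ccccc2)cc(OC)c1O`: 60500 nM
Compound 2 `COc1cc(/C=N/Nc2nc3ccccc3s2)cc(OC)c1O`: "not determined" (no result reported)
Compound 3 `COc1cc(/C=N/NC(=O)OCc2ccccc2)cc(OC)c1OC`: > 1000000 nM

In a physicochemical assay, read by spectrophotometry (a lower number here means a stronger inhibitor, a higher number a weaker inhibitor), compound 1 gives 60500 nM. For compound 2, this assay reports "not determined" (no result reported). Compound 3 gives in this assay only a limit, > 1000000 nM. Compound 3 sits at the limit of > 1000000 nM in this assay, at which 1 of the 3 values shown sits.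

Compound 1 and compound 3 differ in one place: methyl in place of hydrogen on an oxygen on an aromatic ring. That change made a step of an at least 16-fold higher number from compound 1 to compound 3 (1.21 log units; beyond the scatter), a large loss.

Compound 4 `COc1cc(/C=N/Nc2nc3ccccc3s2)cc(OC)c1OC` is the unmeasured member of the set. It differs from compound 2 by methyl in place of hydrogen on an oxygen on an aromatic ring, the same change that separates compound 1 from compound 3, made on the same kind of oxygen in the same surroundings. How the core of compound 2 differs from the core of compound 1 is not broken down here.

Going by the values given here, with no single number for compound 2, the only guide to compound 4 is the step the change made once already. Since compound 1 was itself a weak inhibitor and the change from compound 1 to compound 3 drove the value past the limit, the same change is expected to leave compound 4 weak as well, quite possibly reported only as a limit. Compound 4 is expected near 500000 nM, estimated to lie between 80000 nM and 3000000 nM in this assay.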

Compound 4, half-maximal inhibitory concentration: 43100 nM
Estimate against measurement, compound 4: 12-fold (1.06 log units) above; the whole stated range lies above it.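

In this assay, going by these compounds alone, compound 2 stands at "not determined" (no result reported), while compound 4 gives 43100 nM, so no step from compound 2 to compound 4 can be read. The compounds shown leave open whether hydroxy to methoxy on the core of compound 2 makes a step like the one seen on the core of compound 1, or any step at all.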